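Methoxy Added to the Anilino Ring of Compound 1

The source may hold more compounds than are shown below. What is called first, only, known or untested is meant among the compounds shown, and "the series" means these compounds.

Compound 1 `Cc1nc(SCC(=O)Nc2nc(-c3ccc(Cl)cc3)cs2)n(Nc2ccccc2)c1C` was tested in a functional assay on SK-MEL-5 cells (Homo sapiens) for antiproliferative activity, read by sulforhodamine B assay, with a stated time of 48 h (a higher number here means a weaker inhibitor of growth, a lower number a stronger inhibitor of growth), and gave 6310 nM. Compound 2 `Cc1ccc(Nn2c(SCC(=O)Nc3nc(-c4ccccc4)cs3)nc(C)c2C)cc1`, which carries a methyl group on its anilino ring, gave 5720 nM in this assay; the two numbers lie within the usual scatter of each other. Compound 3 `COc1ccc(Nn2c(SCC(=O)Nc3nc(-c4ccc(Cl)cc4)cs3)nc(C)c2C)cc1` is the unmeasured partner, differing from compound 1 by methoxy in place of hydrogen on an aromatic carbon. Among the compounds with values here, no measured pair shows what this change does. Compound 3 is expected to give 5000 nM, likely between 2000 nM and 15000 nM. The estimated change amounts to a 1.3-fold lower number from compound 1 to compound 3 (0.10 log units; within the scatter), not clearly beyond the scatter.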

Compound 3, concentration for total growth inhibition: 3350 nM
For compound 3 the middle estimate is 1.5-fold (0.17 log units) above the measured one; low and high end bracket the measured number.
By their numbers in this assay, from the lowest: compounds 3, 2 and 1 (each within the scatter of the next).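

Within the data shown here, with methoxy in place of hydrogen on the anilino ring, para to a large group, this assay gives the first direct reading of this change: a 1.9-fold lower number from compound 1 to compound 3 (0.27 log units; within the scatter). The added group therefore leaves growth inhibition indistinguishable from that of the unsubstituted ring, so this single pair shows that the position accepts methoxy without a clear loss or gain. Nothing available explains this result.

Going by these compounds, whether an amine, a carboxylic acid or a longer chain such as ethoxy would move the number beyond the scatter remains open. So does whether methoxy elsewhere on this ring would give the same reading.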